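Pyridin-4-yl to 1H-pyrazol-5-yl: outlook for compound 4

The source may report more compounds than this note shows. Statements on the series, on what has been measured and on what is new or still open speak of the compounds shown alone.

Values in a physicochemical assay for solubility, in phosphate buffer, with a stated time of 18 h; a higher number here means a more soluble compound, a lower number a less soluble compound:
- compound 1 `CC(C)(C)c1nc(C2CCCC2)c2c(N)c(C#N)c(N)nc2n1`: < 1000 nM (a limit, not a number)
- compound 2 `CC(C)(C)c1nc(-c2ccccn2)c2c(N)c(C#N)c(N)nc2n1`: 87000 nM
- compound 3 `CC(C)(C)c1nc(-c2ccncc2)c2c(N)c(C#N)c(N)nc2n1`: 44000 nM

Compound 3 stands level with compound 2, the step being a 2.0-fold lower number from compound 2 to compound 3 (0.30 log units; within the scatter). Compound 4 `CC(C)(C)c1nc(-c2ccn[nH]2)c2c(N)c(C#N)c(N)nc2n1` differs from compound 3 by 1H-pyrazol-5-yl in place of pyridin-4-yl on an aromatic carbon. The closest guide is the exchange of pyridin-2-yl for pyridin-4-yl, a 2.0-fold lower number from compound 2 to compound 3 (0.30 log units; within the scatter). Two large steps, an at least 87-fold higher number from compound 1 to compound 2 (1.93 log units; beyond the scatter) and an at least 44-fold higher number from compound 1 to compound 3 (1.64 log units; beyond the scatter), both start from cyclopentyl and from a limit, so they bear less directly. No step beyond the scatter is expected in this assay. The expected step is a 1.3-fold lower number from compound 3 to compound 4 (0.10 log units; within the scatter). Compound 4 is estimated at 35000 nM, with an expected range of 9000 nM to 100000 nM.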

Compound 4, solubility: 13500 nM
Estimate against measurement, compound 4: 2.6-fold (0.41 log units) above; measured number inside the range.
By their numbers in this assay, from the lowest: compound 4; then compounds 3 and 2 (each within the scatter of the next). At a limit, below all of these: compound 1.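

In this assay, this position now tells aromatic rings apart: the two pyridines stood level, whereas 1H-pyrazol-5-yl gives a 3.3-fold lower number from compound 3 to compound 4 (0.51 log units; beyond the scatter) and a 6.4-fold lower number from compound 2 to compound 4 (0.81 log units; beyond the scatter). Even so, 1H-pyrazol-5-yl stays well clear of cyclopentyl, with an at least 13-fold higher number from compound 1 to compound 4 (1.13 log units; beyond the scatter). Compound 1 is a limit, not a number: the limit of < 1000 nM in this assay, at which 1 of the 4 values shown sits.

Ring size and the hydrogen-bond donor change together in compound 4, so the compounds shown cannot separate them. On these data alone, how a phenyl ring or a methyl-substituted pyrazole would read at this position remains open.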